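The source may hold more compounds than are shown below. What is called first, only, known or untested is meant among the compounds shown, and "the series" means these compounds.

In a functional assay on B16-F10 cells (Mus musculus) for antiproliferative activity, read by MTT assay, with a stated time of 48 h (on this read-out lower numbers stand for stronger inhibition and higher numbers for weaker inhibition), the measured compounds read as follows:
- compound 1 `COc1ccccc1N1CCN(C(=O)/C=C/c2ccc(O)c(O)c2)CC1` gives 1.23 ug/mL in this series
- compound 2 `O=C(/C=C/c1ccc(O)c(O)c1)N1CCN(c2cccc(C(F)(F)F)c2)CC1` gives 2.01 ug/mL in this series
- compound 3 `O=C(/C=C/c1ccc(O)c(O)c1)N1CCN(c2ccc([N+](=O)[O-])cc2)CC1` gives 1.79 ug/mL in this series

Compound 1 cannot be ranked against the other two, as it sits within the scatter of both compound 2 and compound 3. Within the data shown here, the only single-place step measured from it is a 1.5-fold higher number from compound 1 to compound 3 (0.16 log units; within the scatter), which exchanges one substituted phenyl group for another on the same ring nitrogen.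

Compound 4 `CCN1CCN(C(=O)/C=C/c2ccc(O)c(O)c2)CC1` is a larger change, (ethyl in place of 2-methoxyphenyl on an amine nitrogen in a ring), which removes the aromatic ring from that nitrogen. Among the measured compounds shown here, all three measured compounds keep an aromatic ring there, so no measured step tests this exchange directly, and a 1.5-fold higher number from compound 1 to compound 3 (0.16 log units; within the scatter) is only a weak guide. A modest rise in the number is therefore expected in this assay, with wide uncertainty. The estimated change is a 2.0-fold higher number from compound 1 to compound 4 (0.29 log units; within the scatter) in this read-out. Compound 4 is expected at 2.4 ug/mL here, with an estimated range from 1 ug/mL to 6 ug/mL overall.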

Compound 4, half-maximal inhibitory concentration: 6.44 ug/mL
For compound 4 the middle estimate is 2.7-fold (0.43 log units) below the measured one; measured number above the stated range.
By their numbers in this assay, from the lowest: compounds 1, 3 and 2 (each within the scatter of the next); then compound 4.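

Among these compounds, the amine nitrogen in the ring was so far seen only with substituted phenyl groups, and their values in this assay stayed within the scatter of one another. Ethyl at this position gives the first steps beyond the scatter, with a 5.2-fold higher number from compound 1 to compound 4 (0.72 log units; beyond the scatter) and a 3.6-fold higher number from compound 3 to compound 4 (0.56 log units; beyond the scatter), so the two aromatic groups compared here both give lower numbers than ethyl. No measurement on hand accounts for these steps.

The compounds shown do not separate the absence of an aromatic ring from the smaller size of the group, as ethyl differs from 2-methoxyphenyl and 4-nitrophenyl in both respects. A cyclohexyl group, a benzyl group or a longer alkyl chain such as n-butyl on the same nitrogen would address that question.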